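Adding a methyl to the sulfur chain of compound 3

A few compounds are considered here, and "the series" means these few. Any claim that something is new, unique, unknown or untested is made for them only; others in the source may bear on it.

Measured so far (a functional assay on MT4 cells (Homo sapiens) for cytotoxicity; on this read-out higher numbers stand for lower toxicity in this test and lower numbers for higher toxicity in this test):
Compound 1 (`CCC(C)Sc1nc(O)cc(Cc2c(F)cccc2F)n1`): > 200000 nM (a limit)
Compound 2 (`CCC(c1cc(O)nc(SC(C)C)n1)c1c(F)cccc1F`): 130000 nM
Compound 3 (`CC(C)Sc1nc(O)cc(C(C)c2c(F)cccc2F)n1`): 167000 nM

Compound 3 (167000 nM) stands within the scatter of compound 2 (130000 nM). For compound 1 the reading is only a limit (the limit of > 200000 nM in this assay, at which 1 of the 3 values shown sits). The next compound, compound 4 (`CCC(C)Sc1nc(O)cc(C(C)c2c(F)cccc2F)n1`), differs from compound 3 by one change (methyl in place of hydrogen on a saturated chain carbon, two bonds along the chain from a sulfur), which turns isopropylsulfanyl to (sec-butyl)sulfanyl. Compound 1 carries the same (sec-butyl)sulfanyl group. For the measured compounds named here, the one measured step of this kind, methyl against hydrogen, lies at another place on the molecule and stays within the scatter (a 1.3-fold higher number from compound 2 to compound 3 (0.11 log units; within the scatter)). On that basis, no change beyond the scatter is expected in this assay here. The estimated step is small (a 1.0-fold lower number from compound 3 to compound 4 (0.02 log units; within the scatter)). A reading that gives only a limit would not be surprising for compound 4. The expected value for compound 4 is an estimate (160000 nM), with an expected range from 90000 nM to 280000 nM.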

Compound 4, half-maximal cytotoxic concentration: > 200000 nM
Compound 4: no number, only a limit; the forecaster's own chance of this, stated with the estimate: 35%; at least 1.2-fold (0.09 log units) between middle value and limit.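

In this assay, compound 4 gives only a limit, > 200000 nM. Turning isopropylsulfanyl into (sec-butyl)sulfanyl gives an at least 1.1-fold higher number from compound 3 to compound 4 (0.07 log units; that floor lies within the scatter), so this methyl, on a saturated chain carbon two bonds along the chain from a sulfur, shows no step beyond the scatter, only a floor within it. Compound 1 and compound 4, which both carry the (sec-butyl)sulfanyl group, each give a limit, and the step between them cannot be read: the limit of > 200000 nM in this assay, at which 2 of the 4 values shown sit.

The compounds shown leave open how far the readings of compound 1 and compound 4 lie past that limit, and so whether (sec-butyl)sulfanyl differs at all from isopropylsulfanyl in this assay. Also open, going by these compounds, is how this read-out would respond to a longer chain on the sulfur, or to an amine or a carboxylic acid on that chain.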